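The source may hold more compounds than are shown below. What is called first, only, known or untested is meant among the compounds shown, and "the series" means these compounds.

Measured so far:
compound 1, `O=C(Nc1cccc(-n2cc(-c3ccncc3)c(-c3ccc(Cl)c(O)c3)n2)c1)Nc1cccc(C(F)(F)F)c1` — 2140 nM
compound 2, `COc1cc(-c2nn(-c3cccc(NC(=O)Nc4ccc(Cl)c(Cl)c4)c3)cc2-c2ccncc2)ccc1Cl` — 990 nM
compound 3, `COc1cc(-c2nn(-c3cccc(NC(=O)Nc4cccc(C(F)(F)F)c4)c3)cc2-c2ccncc2)ccc1Cl` — 783 nM

All three share a core and were tested in a functional assay on NCI/ADR-RES cells (Homo sapiens) for inhibition, read by sulforhodamine B assay, with a stated time of 48 h; a lower number here means a stronger inhibitor of growth, a higher number a weaker inhibitor of growth. Compound 3 gives the lowest number of the three, but the step of a 1.3-fold lower number from compound 2 to compound 3 (0.10 log units; within the scatter) is within the scatter, so compound 2 and compound 3 cannot be told apart; only compound 1 stands clearly apart, with a 2.7-fold lower number from compound 1 to compound 3 (0.44 log units; beyond the scatter).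

Compound 4, `COc1cc(-c2nn(-c3cccc(NC(=O)c4ccccc4)c3)cc2-c2ccncc2)ccc1Cl`, has not yet been measured in this assay. It differs from compound 3 in one place: phenyl in place of (3-(trifluoromethyl)phenyl)amino on a carbonyl carbon. The nitrogen-bearing, fluorinated arm on the carbonyl is gone, and a plain phenyl sits directly on the carbonyl carbon instead.

For the measured compounds named here, of the measured steps, only the one from compound 2 to compound 3 touches that region, and it swapped one aryl group for another on the amide-type nitrogen, within the scatter. Going by the values given here, no measured step removes the amide-type nitrogen itself, so the change to compound 4 is larger than anything seen here. With that, and the hydrogen-bond donor counted as leaving, a weaker inhibitor is expected, and the step from compound 3 to compound 4 in this assay is estimated at a 3.8-fold higher number from compound 3 to compound 4 (0.58 log units; beyond the scatter). Compound 4 is therefore expected to give about 3000 nM, most likely between 800 nM and 12000 nM.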

Compound 4, concentration for 50% growth inhibition: 448 nM
Estimate against measurement, compound 4: 6.7-fold (0.83 log units) above; measured number outside the range, below it.
By their numbers in this assay, from the lowest: compounds 4, 3 and 2 (each within the scatter of the next, the first and the last beyond it); then compound 1.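

For the compounds shown here, until now, the only change near the carbonyl swapped one aryl group for another on the amide-type nitrogen; compound 4 shows that the amino link and its amide hydrogen can leave this position altogether, with the phenyl sitting directly on the carbonyl carbon, and growth inhibition in this assay is still retained. With a 1.7-fold lower number from compound 3 to compound 4 (0.24 log units; within the scatter), compound 3 and compound 4 cannot be told apart, so the (3-(trifluoromethyl)phenyl)amino arm shows no measurable advantage over plain phenyl here, whereas a 2.2-fold lower number from compound 2 to compound 4 (0.34 log units; beyond the scatter) is a modest gain over the (3,4-dichlorophenyl)amino arm. No measurement available here explains why the simpler group holds up this well.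

As far as these compounds go, it remains open whether a phenyl on the carbonyl carbon bearing a trifluoromethyl group or a chlorine would change the number, and whether a cyclohexyl ring or a short alkyl chain could replace the phenyl altogether. Also open, from the compounds shown here alone, is whether a free hydroxyl in place of the methoxy group on the chlorinated ring would cost as much with this phenyl amide as it does within the pair of compound 1 and compound 3.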